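The source may report more compounds than this note shows. Statements on the series, on what has been measured and on what is new or still open speak of the compounds shown alone.

Measured compounds and their values in a functional assay on A549 cells (Homo sapiens) for cytotoxicity, read by MTT assay, with a stated time of 48 h; on this read-out lower numbers stand for stronger inhibition and higher numbers for weaker inhibition:

Compound 1, `CC(C)=CCC/C(C)=C/CC/C(C)=C/CC[C@@H]1[C@@]2(C)CCC(=O)C(C)(C)[C@@H]2CC[C@@]1(C)O`: 12000 nM
Compound 2, `CC(C)=CCC/C(C)=C/CC/C(C)=C/CC[C@@H]1[C@@]2(C)CC/C(=N\OCc3cn(-c4ccccc4)nn3)C(C)(C)[C@@H]2CC[C@@]1(C)O`: 6160 nM
Compound 3, `CC(C)=CCC/C(C)=C/CC/C(C)=C/CC[C@@H]1[C@@]2(C)CC/C(=N\OCc3cn(-c4ccc(Cl)cc4)nn3)C(C)(C)[C@@H]2CC[C@@]1(C)O`: 12300 nM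

Compound 3 carries the highest of the three numbers in this assay, yet its gap to compound 1 and its gap to compound 2 both lie within the scatter of repeated measurements, so the three compounds cannot be told apart on these numbers.

Compound 4, `CC(C)=CCC/C(C)=C/CC/C(C)=C/CC[C@@H]1[C@@]2(C)CC/C(=N\OCc3cn(-c4cccc(C(F)(F)F)c4)nn3)C(C)(C)[C@@H]2CC[C@@]1(C)O`, differs from compound 3 in one place: 3-(trifluoromethyl)phenyl in place of 4-chlorophenyl on an aromatic nitrogen. Within the data shown here, only one measured step bears on this change, the one in which a chloro replaced a hydrogen on the same aromatic ring: a 2.0-fold higher number from compound 2 to compound 3 (0.30 log units; within the scatter). That change on the phenyl ring left the number within the scatter, so swapping the substituted phenyl ring for another substituted phenyl ring is expected to do the same in this assay. For compound 4 the estimated step is a 1.1-fold lower number from compound 3 to compound 4 (0.05 log units; within the scatter), no more than the scatter. Compound 4 is therefore expected to give about 11000 nM, between 4500 nM and 28000 nM.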

Compound 4, half-maximal inhibitory concentration: 12900 nM
Beside the measured number, compound 4's estimate is 1.2-fold (0.07 log units) below it; the measured number falls inside the stated range.
By their numbers in this assay, from the lowest: compounds 2, 1, 3 and 4 (each within the scatter of the next, the first and the last beyond it).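

In this assay, putting 3-(trifluoromethyl)phenyl in place of 4-chlorophenyl on the aromatic nitrogen gives a 1.0-fold higher number from compound 3 to compound 4 (0.02 log units; within the scatter), so these two substituted phenyl rings cannot be told apart on this read-out, even though the group and its place on the ring both change. Set against the unsubstituted phenyl, trifluoromethyl in place of hydrogen gives a 2.1-fold higher number from compound 2 to compound 4 (0.32 log units; beyond the scatter), a modest step and the only one shown that passes the scatter, while the chloro step, a 2.0-fold higher number from compound 2 to compound 3 (0.30 log units; within the scatter), stays within it. Nothing measured here explains these numbers.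

As far as these compounds go, it remains open whether 3-chlorophenyl would match 4-chlorophenyl, which would separate the effect of the group from that of its place on the ring. Also open, from the compounds shown here alone, is how a ring carrying an amine or a carboxylic acid would behave at this position.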